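Fluoro for chloro on the aryl ring of compound 3

The source may report more compounds than this note shows. Statements on the series, on what has been measured and on what is new or still open speak of the compounds shown alone.

Measured compounds:
compound 1 `O=C(O)Cc1sc(Nc2ccccc2)nc1-c1ccc(F)cc1`: 650 nM
compound 2 `O=C(O)Cc1sc(Nc2ccc(Cl)cc2)nc1-c1ccc(F)cc1`: 960 nM
compound 3 `O=C(O)Cc1sc(Cc2ccccc2)nc1-c1ccc(Cl)cc1`: 180 nM

In an in vitro assay on COS-7 cells for displacement of a labelled ligand from prostaglandin D2 receptor 2 (Homo sapiens) (a higher number here means a weaker inhibitor, a lower number a stronger inhibitor), compound 3 gives the lowest of the three numbers. Its nearest neighbour is compound 1, which gives 650 nM, and compound 2 gives 960 nM; both gaps to compound 3 lie beyond the scatter, so compound 3 stands apart as the strongest inhibitor among the three. Going by the values given here, compound 1 and compound 3 differ in two places at once, so their values alone show only that the two changes together lower the number.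

Compound 4 `O=C(O)Cc1sc(Cc2ccccc2)nc1-c1ccc(F)cc1` is the unmeasured partner of compound 3. The change is fluoro in place of chloro on an aromatic carbon. Among the compounds with values here, no measured pair shows this swap. Within the data shown here, the only single step recorded, a 1.5-fold higher number from compound 1 to compound 2 (0.17 log units; within the scatter), concerns a different ring, where chloro replaced hydrogen; it stayed within the scatter. That step is a weak guide at best, but it gives no sign that a change of this kind moves the number far. Compound 4 is therefore expected to give about 260 nM in this assay, within 120 nM to 560 nM, which means an estimated step of a 1.4-fold higher number from compound 3 to compound 4 (0.16 log units; within the scatter), likely no larger than the scatter.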

Compound 4, half-maximal inhibitory concentration: 140 nM
Compound 4: middle estimate off by 1.9-fold (0.27 log units), on the high side; low and high end bracket the measured number.
By their numbers in this assay, from the lowest: compounds 4 and 3 (each within the scatter of the next); then compounds 1 and 2 (each within the scatter of the next).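

In this assay, going from 4-chlorophenyl to 4-fluorophenyl gives a 1.3-fold lower number from compound 3 to compound 4 (0.11 log units; within the scatter), so the two halogens on this aromatic carbon, para to a large group, cannot be told apart in this assay. Compound 4 also shares its 4-fluorophenyl group with compound 1 and compound 2, which isolates a change that compound 3 could not show alone: benzyl in place of anilino gives a 4.6-fold lower number from compound 1 to compound 4 (0.67 log units; beyond the scatter), and benzyl in place of (4-chlorophenyl)amino gives a 6.9-fold lower number from compound 2 to compound 4 (0.84 log units; beyond the scatter), both beyond the scatter, so in these two single-place comparisons the larger shift comes from the benzyl exchange rather than from the halogen exchange. No supporting measurement is available to explain any of these steps.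

The compounds shown leave open whether the same insensitivity would extend to a methoxy, nitrile or trifluoromethyl group at the position para to a large group, since only the two halogens appear there. They also leave open how the number would respond to a longer chain, such as phenethyl, in place of benzyl, or to an ester or tetrazole in place of the carboxylic acid.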